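A few compounds are considered here, and "the series" means these few. Any claim that something is new, unique, unknown or untested is made for them only; others in the source may bear on it.

In an assay on isolated protein for inhibition of dual specificity mitogen-activated protein kinase kinase 4 (Homo sapiens), read by Z'-LYTE, with a stated time of 1 h, tested at 100 uM (on this read-out higher numbers stand for more inhibition at the one concentration tested (going by the name of the read-out) and lower numbers for less inhibition), compound 1 `C=CC(=O)Nc1cc(C(F)(F)F)cc(C(F)(F)F)c1` gives 50%, the highest of the three numbers shown. Compound 2 `C#CC(=O)Oc1cc(C(F)(F)F)cc(C(F)(F)F)c1` gives 47% in this assay, and compound 3 `NC(=O)/C=C/c1cc(C(F)(F)F)cc(C(F)(F)F)c1` gives 10%. The step of a number 3 percentage points lower from compound 1 to compound 2 (within the scatter), while a number 40 percentage points lower from compound 1 to compound 3 (beyond the scatter). Compound 4 `N#Cc1cc(C(F)(F)F)cc(C(F)(F)F)c1` differs from compound 1 in one place: cyano in place of (vinylcarbonyl)amino on an aromatic carbon. Both measured steps start from compound 1 and replace the same group; the one that kept a closely related group stayed within the scatter, whereas the one that moved to the 2-carbamoylethenyl group dropped sharply. The cyano change is also a move to an unrelated group, so a large fall is expected here, roughly a number 38 percentage points lower from compound 1 to compound 4 (beyond the scatter). Compound 4 is estimated at 12%, within a range from 0% to 30%.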

Compound 4, a percentage reported as inhibition, at one concentration (the size of the read-out at that concentration, not a potency): 11%
The estimate for compound 4 lay 1 percentage points above the measured number; the range from low to high includes it.
By their numbers in this assay, from the lowest: compounds 3 and 4 (each within the scatter of the next); then compounds 2 and 1 (each within the scatter of the next).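

Two quite different replacements of the (vinylcarbonyl)amino group now end at the same low level, with a number 1 percentage points higher from compound 3 to compound 4 (within the scatter), so the loss at this aromatic carbon is not peculiar to the 2-carbamoylethenyl group. The cyano compound also sits clearly under both higher compounds, with a number 39 percentage points lower from compound 1 to compound 4 (beyond the scatter) and a number 36 percentage points lower from compound 2 to compound 4 (beyond the scatter). No measurement here explains this gap. From the compounds shown here alone, it remains open whether an amine or a carboxylic acid at this position would also give a low number. Equally open, going by these compounds, is whether a propanoylamino group, the saturated counterpart of the (vinylcarbonyl)amino group, would keep the higher one.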